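This account rests on a few compounds, and the source may have more. Where it says the series, first, only, none or still open, it means among the compounds named here.

Measured compounds in a functional assay on CCRF-CEM cells (Homo sapiens) for antiproliferative activity; a higher number here means a weaker inhibitor, a lower number a stronger inhibitor:
compound 1, `COc1cc(C(=O)c2sc(-c3ccc(C)cc3)cc2N)cc(OC)c1OC`, gives 15 nM
compound 2, `COc1cc(C(=O)c2sc(-c3ccc(F)cc3)cc2N)cc(OC)c1OC`, gives 15 nM
compound 3, `COc1cc(C(=O)c2sc(-c3cc(OC)c(OC)c(OC)c3)cc2N)cc(OC)c1OC`, gives 840 nM

Compound 2 sits level with compound 1 at the digits shown, the two together holding the lowest numbers of the three, while compound 3 stands far higher, a gap well beyond the scatter. For the measured compounds named here, the only single-point step measured so far, no change at the digits printed from compound 1 to compound 2 (within the scatter), left the read-out where it was.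

Compound 4, `CCOc1ccc(-c2cc(N)c(C(=O)c3cc(OC)c(OC)c(OC)c3)s2)cc1`, has not yet been run. Against compound 2 the change is ethoxy in place of fluoro on an aromatic carbon. Going by the values given here, no measured step speaks directly to ethoxy on this aromatic carbon. What the series does show is that swapping one small group for another on that carbon, as from compound 1 to compound 2, costs nothing, whereas compound 3, carrying three methoxy groups on the same ring, gives a much higher number; that is a different and heavier change. An ethoxy is a single group, so a collapse of the kind seen with compound 3 is not expected, but a modest rise seems more likely than none. Compound 4 is expected to give 30 nM, within 8 nM to 150 nM, which amounts to an estimated step of a 2.0-fold higher number from compound 2 to compound 4 (0.30 log units; within the scatter).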

Compound 4, half-maximal inhibitory concentration: 270 nM
For compound 4 the middle estimate is 9.0-fold (0.95 log units) below the measured one; measured number outside the range, above it.
By their numbers in this assay, from the lowest: compounds 1 and 2 (each within the scatter of the next); then compound 4; then compound 3.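

In this assay this aromatic carbon proves less tolerant than the earlier pair suggested: ethoxy in place of fluoro gives an 18-fold higher number from compound 2 to compound 4 (1.26 log units; beyond the scatter) and ethoxy in place of methyl gives an 18-fold higher number from compound 1 to compound 4 (1.26 log units; beyond the scatter) so one single group here is enough to move the read-out beyond the scatter. The flat step of no change at the digits printed from compound 1 to compound 2 (within the scatter) therefore holds for methyl and fluoro only and does not extend to every single group on this carbon. No supporting data are available to account for the rise, and the measured compounds do not separate the oxygen of ethoxy from its larger count of heavy atoms as the feature that matters.

From the compounds shown here alone, whether hydroxy, which also places an oxygen on this carbon, tracks with ethoxy or with methyl and fluoro remains open. Also open, going by these compounds, is whether a longer chain such as propoxy raises the number further or whether an amine on the same carbon returns it towards the level of compound 1 and compound 2.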